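Same Substitution Twice: Forecasting the Second Step

The source may report more compounds than this note shows. Statements on the series, on what has been measured and on what is new or still open speak of the compounds shown alone.

All three measured compounds were tested in a functional assay on MDA-MB-435 cells (Homo sapiens) for inhibition; on this read-out lower numbers stand for stronger inhibition and higher numbers for weaker inhibition.

Compound 1 `O=C(O)COc1ccc(/C=C/C(=O)c2ccc(Cl)c(Cl)c2)cc1` gives 13000 nM.
Compound 2 `O=C(/C=C/c1ccc(B(O)O)cc1)c1ccc(Cl)c(Cl)c1` gives 4000 nM.
Compound 3 `O=C(O)COc1ccc(C(=O)/C=C/c2ccc(Cl)c(Cl)c2)cc1` gives 9000 nM.

Compound 4 `O=C(/C=C/c1ccc(Cl)c(Cl)c1)c1ccc(B(O)O)cc1` has not yet been measured in this assay.

Compound 2 differs from compound 1 in one place: a group of 3 heavy atoms (1 boron, 2 oxygen; no ring) in place of a group of 5 heavy atoms (2 carbon, 3 oxygen; no ring), on an aromatic carbon. That single change produced a 3.3-fold lower number from compound 1 to compound 2 (0.51 log units; beyond the scatter), a clear step beyond the usual scatter. Compound 4 carries the very same change relative to compound 3: a group of 3 heavy atoms (1 boron, 2 oxygen; no ring) in place of a group of 5 heavy atoms (2 carbon, 3 oxygen; no ring), on an aromatic carbon. The surroundings of the exchanged group are described in identical words in both cases, so this is the same change made on a second core. How the core of compound 1 and the core of compound 3 differ is not broken down here; the two hold the same atoms joined differently. The numbers of compound 1 and compound 3 lie within the scatter of each other, so the two cores start from comparable ground.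

The change occurs only twice among the compounds shown, and the one measured instance is the whole basis for a forecast. Because the change gave a 3.3-fold lower number from compound 1 to compound 2 (0.51 log units; beyond the scatter) on the first core, a step of about the same size is expected on the second, namely a 3.0-fold lower number from compound 3 to compound 4 (0.48 log units; beyond the scatter). Compound 4 is accordingly estimated at 3000 nM in this assay. For compound 4 the expected range runs from 1200 nM to 7500 nM.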

Compound 4, half-maximal inhibitory concentration: 3500 nM
Estimate against measurement, compound 4: 1.2-fold (0.07 log units) below; low and high end bracket the measured number.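

In this assay, replacing carboxymethoxy with the boron-bearing group again lowered the number, giving a 2.6-fold lower number from compound 3 to compound 4 (0.41 log units; beyond the scatter), so the change that worked on the core of compound 1 also worked on the core of compound 3. The two steps point the same way and do not differ in size by more than can be expected from repeated measurements: the same change on two cores in this assay, a 3.3-fold lower number (0.51 log units; beyond the scatter) from compound 1 to compound 2 and a 2.6-fold lower number (0.41 log units; beyond the scatter) from compound 3 to compound 4, 1.3-fold (0.10 log units) apart, within the scatter of two such steps. This shows that, on these two cores, which hold the same atoms joined differently, the effect of the change carried over; it does not show that the step would hold on any other core, and the numbers alone do not explain why the change lowers the value.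

The exchanged place carries only carboxymethoxy or the boron-bearing group in the compounds shown, so it remains open how an amine, a methyl ester or a longer chain would compare there. All four compounds also keep the same two chlorine atoms, which leaves open whether the step would survive on a core without them, and whether it would appear in any read-out other than this assay.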